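Compound 1 and the step to compound 4

A few compounds are considered here, and "the series" means these few. Any claim that something is new, unique, unknown or untested is made for them only; others in the source may bear on it.

Compound 1 `c1ccc2c(c1)CN[C@H](CN(CCCN1CCNCC1)[C@H]1CCCc3cccnc31)C2` gives 88%
Compound 2 `CC(C)N1CCN(CCCN(C[C@H]2Cc3ccccc3CN2)[C@H]2CCCc3cccnc32)CC1` gives 58%
Compound 3 `NC(=O)N1CCN(CCCN(C[C@H]2Cc3ccccc3CN2)[C@H]2CCCc3cccnc32)CC1` gives 42%

Compound 1 stands highest of the three in an ADME assay on microsomes from liver (Mus musculus) for metabolic stability, read by LC-MS, with a stated time of 10 min, tested at 0.5 uM; on this read-out lower numbers stand for a less stable compound and higher numbers for a more stable compound (at 88%), and compound 2 (58%) and compound 3 (42%) both lie below it by more than the scatter.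

Compound 4 (`c1cnc2c(c1)CCC[C@@H]2N(CCCN1CCNCC1)Cc1nc2ccccc2[nH]1`) has not yet been measured. It differs from compound 1 by 1H-benzimidazol-2-yl in place of 1,2,3,4-tetrahydroisoquinolin-3-yl on a saturated chain carbon bound to an amine nitrogen.

Going by the values given here, compounds 2 and 3 keep the group that leaves, so no measured compound carries the group that enters. Among the compounds with values here, the only measured step (a number 16 percentage points lower from compound 2 to compound 3 (beyond the scatter)) is modest but lies beyond the scatter. It is carbamoyl in place of isopropyl on an amine nitrogen in a ring, which is a different place, so it offers only a rough size for what a single change has done among these compounds. Compound 1 (at 88%) sits near the top of the scale, leaving more room to fall than to rise.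

The expected step is of similar size and downward (a number 18 percentage points lower from compound 1 to compound 4 (beyond the scatter)), though this is only an estimate. For compound 4 the estimated value in this assay is 70% (expected range 48% to 88%).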

Compound 4, percent of the compound remaining: 68%
Beside the measured number, compound 4's estimate is 2 percentage points above it; the range from low to high includes it.
By their numbers in this assay, from the lowest: compound 3; then compounds 2 and 4 (each within the scatter of the next); then compound 1.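

Replacing 1,2,3,4-tetrahydroisoquinolin-3-yl with 1H-benzimidazol-2-yl on a saturated chain carbon bound to an amine nitrogen gives a number 20 percentage points lower from compound 1 to compound 4 (beyond the scatter) in this assay and so shows that this place, which the earlier step between two measured compounds did not touch, bears on the read-out. The two groups have the same printed counts of hydrogen-bond donors and acceptors and neither has a net charge, so those counts do not separate them; they differ in that a five-membered aromatic ring with 2 hetero atoms replaces a six-membered non-aromatic ring with 1 hetero atom, and in that the defined stereocentre of the leaving group is gone. Nothing shown here gives a cause for the step.

The compounds shown leave open whether the same exchange would give a step of similar size with the isopropyl of compound 2 or the carbamoyl of compound 3 on the amine nitrogen in a ring. They also leave open where a simple primary amine or a carboxylic acid on that saturated chain carbon would stand in this assay relative to either group.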